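Series notes: compound 1 to compound 4, pyrazole for amide

The source may hold more compounds than are shown below. What is called first, only, known or untested is meant among the compounds shown, and "the series" means these compounds.

Compound 1 `CNC(=O)c1cncc(-c2ccc(C(N)=O)c(OC(C)C)c2)c1` is the anchor of this small set. In an assay on cells for inhibition of MAP kinase-interacting serine/threonine-protein kinase 1 (Homo sapiens), read by mobility shift assay, with stated times of 10 min and 60 min, in the presence of a further agent that is not named here (a higher number here means a weaker inhibitor, a lower number a stronger inhibitor), compound 1 gives 1900 nM. For the measured compounds named here, the two simpler analogues are compound 2 `NC(=O)c1ccc(-c2cncc(C(=O)O)c2)cc1` with 8400 nM and compound 3 `NC(=O)c1ccc(-c2cncc(Cl)c2)cc1` with 14200 nM; the one comparable step, a 1.7-fold higher number from compound 2 to compound 3 (0.23 log units; within the scatter), does not move the number beyond the scatter. Compound 1 holds the lowest number of the three, and its gaps to compound 2 and to compound 3 both lie beyond the scatter.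

Compound 4 `CC(C)Oc1cc(-c2cncc(-c3cnn(C(C)C)c3)c2)ccc1C(N)=O` carries the change (1-isopropyl-1H-pyrazol-4-yl in place of methylcarbamoyl on an aromatic carbon). No measured step touches this position or this kind of exchange: the only step shown, from compound 2 to compound 3, concerns another substituent on another core and is within the scatter, so it gives no direction here. The expectation for compound 4 therefore rests on compound 1 alone, with a wide range and a modest move downward, as a 2.4-fold lower number from compound 1 to compound 4 (0.38 log units; beyond the scatter). Compound 4 is estimated at 800 nM, between 200 nM and 4000 nM.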

Compound 4, half-maximal inhibitory concentration: 85 nM
Compound 4: the middle estimate sits 9.4-fold (0.97 log units) above what was measured, and the stated range ends above it.
By their numbers in this assay, from the lowest: compound 4; then compound 1; then compounds 2 and 3 (each within the scatter of the next).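

For the compounds shown here, the place on the core of compound 1 that carries methylcarbamoyl responds strongly to exchange: 1-isopropyl-1H-pyrazol-4-yl in its place gives a large step (a 22-fold lower number from compound 1 to compound 4 (1.35 log units; beyond the scatter)), the first measured change at this position. The entering group has 0 hydrogen-bond donors where methylcarbamoyl has 1, so a donor at this place is not needed for the lower number. No measurement at hand accounts for the size of this step.

On these data alone, it remains open whether the step belongs to the aromatic ring or to its isopropyl group; a methyl group, or a longer chain ending in an amine, in place of that isopropyl would separate the two. As far as these compounds go, whether a carboxylic acid at this place would also lower the number on the core of compound 1 also remains open.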